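Solubility notes: compound 3 to compound 4

The source may hold more compounds than are shown below. What is called first, only, known or untested is meant among the compounds shown, and "the series" means these compounds.

Measured compounds in a physicochemical assay for solubility, read by spectrophotometry, in phosphate buffer, with a stated time of 2 h, at pH 7.4; on this read-out higher numbers stand for higher solubility and lower numbers for lower solubility:
Compound 1 `COc1ccc2[nH]c(C(=O)N3CC(=O)N(Cc4ccccc4)[C@@H](CN4CCC(C)CC4)C3)cc2c1` gives 93100 nM.
Compound 2 `COc1cccc(CN2C(=O)CN(C(=O)c3cc4cc(OC)ccc4[nH]3)C[C@@H]2Cc2ccccn2)c1` gives 57900 nM.
Compound 3 `COc1ccc2[nH]c(C(=O)N3CC(=O)N(Cc4ccccc4)[C@@H](Cc4ccccn4)C3)cc2c1` gives > 100000 nM, which is a limit of the assay and not a number.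

Compound 3 therefore stands only as a limit; where it sits above that limit is not known, and so both steps into it are floors. The step of an at least 1.0-fold higher number from compound 1 to compound 3 (0.03 log units; that floor lies within the scatter) puts compound 1 and compound 3 within the scatter of each other; the step of an at least 1.7-fold higher number from compound 2 to compound 3 (0.23 log units; that floor lies within the scatter) concerns a different position and does not bear on the change below.

Compound 4 `COc1ccc2[nH]c(C(=O)N3CC(=O)N(Cc4ccccc4)[C@@H](CN4CC5CCCC5C4)C3)cc2c1` differs from compound 3 by a group of 8 heavy atoms (7 carbon, 1 nitrogen; one five-membered non-aromatic ring of carbon only, one five-membered non-aromatic ring with 1 hetero atom) in place of a group of 6 heavy atoms (5 carbon, 1 nitrogen; one six-membered aromatic ring with 1 hetero atom), on a saturated chain carbon bound to a saturated ring carbon. Within the data shown here, the one measured step at the same place, the saturated chain carbon bound to a saturated ring carbon, is that from compound 1, where 4-methylpiperidin-1-yl and pyridin-2-yl gave numbers not separable beyond the scatter. The group entering compound 4 is, like that of compound 1, saturated with one nitrogen, so no step beyond the scatter is expected in this assay; the expected step is an at least 1.1-fold lower number from compound 3 to compound 4 (0.07 log units; that floor lies within the scatter), with some chance that only a limit is reported again. Compound 4 is expected to give 85000 nM, in a range from 35000 nM to 200000 nM.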

Compound 4, solubility: 20700 nM
For compound 4 the middle estimate is 4.1-fold (0.61 log units) above the measured one; measured number outside the range, below it.
By their numbers in this assay, from the lowest: compound 4; then compounds 2 and 1 (each within the scatter of the next). At a limit, above all of these: compound 3.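

In this assay, the saturated chain carbon bound to a saturated ring carbon now shows a change beyond the scatter, which the earlier step at this place did not, and an at least 4.8-fold lower number from compound 3 to compound 4 (0.68 log units; beyond the scatter) stands as a floor. Two groups that are both saturated and carry one nitrogen also part here, with a 4.5-fold lower number from compound 1 to compound 4 (0.65 log units; beyond the scatter) for the group of compound 4 in place of 4-methylpiperidin-1-yl, so a saturated ring with one nitrogen does not by itself fix the number at this place. Compound 3 stands at a limit of the assay and not at a number, and its step can be read only as a floor because of that limit: the limit of > 100000 nM in this assay, at which 1 of the 4 values shown sits.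

Open, from the compounds shown here alone, is whether the two five-membered rings or the count of heavy atoms goes with the lower number, and where compound 3 truly sits. Also open, going by these compounds, is how morpholin-4-yl, a dimethylamino group or a carboxylic acid on the same saturated chain carbon would read, and whether the step from compound 1 holds with the methoxy group of compound 2 in place.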